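Cyclopentyl for butyl on the sulfonamide nitrogen

This account rests on a few compounds, and the source may have more. Where it says the series, first, only, none or still open, it means among the compounds named here.

Measured so far:
compound 1 `CCCCNS(=O)(=O)c1ccc(Nc2ncc3c(n2)N(C2CCCC2)[C@H](CC)C(=O)N3C)cc1`: 477 nM
compound 2 `CCCCNS(=O)(=O)c1ccc(Nc2ncc3c(n2)N(c2ccn(C)n2)C(CC)C(=O)N3C)cc1`: 10600 nM

In a functional assay on A549 cells (Homo sapiens) for antiproliferative activity, read by CCK-8 assay, with a stated time of 72 h (on this read-out lower numbers stand for stronger inhibition of growth and higher numbers for weaker inhibition of growth), compound 1 gives 477 nM, the lower of the two numbers, and compound 2 gives 10600 nM, a gap beyond the scatter. The next compound to be tested is compound 3 `CC[C@@H]1C(=O)N(C)c2cnc(Nc3ccc(S(=O)(=O)NC4CCCC4)cc3)nc2N1C1CCCC1`, which has cyclopentyl in place of butyl on a sulfonamide nitrogen. The rest of the structure matches compound 1. Going by the values given here, no measured pair shows a change at this place, so the expectation starts from compound 1 at 477 nM. In this assay no step beyond the scatter is expected, and neither direction is favoured. The estimated step of a 1.2-fold higher number from compound 1 to compound 3 (0.06 log units; within the scatter) is small. Compound 3 is expected at 550 nM, with an estimated range of 180 nM to 1700 nM.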

Compound 3, concentration for 50% growth inhibition: 1150 nM
Compound 3: the middle estimate sits 2.1-fold (0.32 log units) below what was measured; measured number inside the range.
By their numbers in this assay, from the lowest: compound 1; then compound 3; then compound 2.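

In this assay, going by these compounds alone, the sulfonamide nitrogen proves sensitive to substitution: cyclopentyl in place of butyl gives a 2.4-fold higher number from compound 1 to compound 3 (0.38 log units; beyond the scatter), the first reading at this place. The step is modest, so a five-membered carbon ring on this nitrogen retains growth inhibition, though it gives weaker inhibition than the butyl chain on the core of compound 1. Nothing available accounts for the loss.

This single pair cannot separate the presence of the ring from the change in chain shape or carbon count, and it gives no trend across substituents at this nitrogen. A pentyl chain would bear on the first question, while a cyclopropyl ring, or a chain ending in an amine or a carboxylic acid, would show how far this position tolerates other groups.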